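Swapping 1-Hydroxyethyl for Acetyl on an Aromatic Carbon

This account rests on a few compounds, and the source may have more. Where it says the series, first, only, none or still open, it means among the compounds named here.

Of the compounds shown here, two built on one shared core have been measured so far. Compound 1 `CCCC(C)n1c(CC)nc2c(-c3ccc(C(C)(C)O)cc3Cl)ccnc21` gives 24 nM in an assay for binding affinity to Corticotropin releasing factor receptor (Rattus norvegicus); a higher number here means a weaker inhibitor, a lower number a stronger inhibitor. Compound 2 `CCCC(C)n1c(CC)nc2c(-c3ccc(C(C)O)cc3Cl)ccnc21`, which carries a hydrogen in place of a methyl on the saturated chain carbon bearing the oxygen, gives 5.1 nM in this assay. Going by the values given here, the step of a 4.7-fold lower number from compound 1 to compound 2 (0.67 log units; beyond the scatter) is the only measured step available, and it leaves compound 2 with the lower of the two numbers.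

Compound 3 `CCCC(C)n1c(CC)nc2c(-c3ccc(C(C)=O)cc3Cl)ccnc21` has not yet been measured. It differs from compound 2 by acetyl in place of 1-hydroxyethyl on an aromatic carbon. No measured step replaces an alcohol by a ketone at this position, so the single step shown, a 4.7-fold lower number from compound 1 to compound 2 (0.67 log units; beyond the scatter), indicates only that a small alteration of this group can move the number by a modest amount. With the hydrogen-bond donor removed and the acceptor kept, the change is expected to be small, possibly toward a somewhat higher number. Compound 3 is estimated at 10 nM in this assay, with a range of 3 nM to 35 nM. This corresponds to an expected step of a 2.0-fold higher number from compound 2 to compound 3 (0.29 log units; within the scatter).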

Compound 3, inhibition constant: 1 nM
The estimate for compound 3 lay 10-fold (1.00 log units) above the measured number; the measured number lies below the stated range.
By their numbers in this assay, from the lowest: compound 3; then compound 2; then compound 1.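

At this position, para to a large group and meta to a chloro group, the alcohol is not needed for a low number in this assay: acetyl has the same heavy-atom count as 1-hydroxyethyl but 0 hydrogen-bond donors, and this swap gives a 5.1-fold lower number from compound 2 to compound 3 (0.71 log units; beyond the scatter). Acetyl in place of the bulkier 1-hydroxy-1-methylethyl gives a 24-fold lower number from compound 1 to compound 3 (1.38 log units; beyond the scatter), the largest step so far, so the three groups now form a series in which the number falls from 1-hydroxy-1-methylethyl through 1-hydroxyethyl to acetyl. No experimental evidence is available to explain why the ketone gives the lowest number of the three.

Still open, going by these compounds, is how far this position tolerates other groups, such as a longer ketone like propanoyl, a carboxylic acid, an amine or a nitrile, any of which would show whether the carbonyl itself matters or acetyl is simply one good fit among many. Also open, on these data alone, is whether the swap from 1-hydroxyethyl to acetyl gives a similar step when the chloro group is replaced, for example by methoxy.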